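A few compounds are considered here, and "the series" means these few. Any claim that something is new, unique, unknown or untested is made for them only; others in the source may bear on it.

Compound 3 `N#Cc1cc(C(F)(F)F)cc(C(F)(F)F)c1` stands at the top of everything measured so far in an ADME assay for pharmacokinetics, read by LC-MS, in phosphate buffer, with a stated time of 72 h, at pH 7.4, tested at 250 uM; a higher number here means that the compound lasts longer, a lower number that the compound disappears faster. In this assay compound 3 gives > 50 h, which is a limit of the assay rather than a number, the one described by the limit of > 50 h in this assay, at which 1 of the 3 values shown sits. Compound 1 `C=CC(=O)Nc1cc(C(F)(F)F)cc(C(F)(F)F)c1` gives 1.8 h in this assay. Compound 2 `C=CS(=O)(=O)c1cc(C(F)(F)F)cc(C(F)(F)F)c1` gives < 0.017 h in this assay, again a limit of the assay, the one described by the limit of < 0.017 h in this assay, at which 1 of the 3 values shown sits. Compound 4 `FC(F)(F)c1cc(C2CO2)cc(C(F)(F)F)c1` differs from compound 3 by a single change: oxiran-2-yl in place of cyano on an aromatic carbon. The measured steps that bear on this are the two that end at compound 3 and concern the cyano group, an at least 27-fold higher number from compound 1 to compound 3 (1.44 log units; beyond the scatter) and an at least 2900-fold higher number from compound 2 to compound 3 (3.46 log units; beyond the scatter); the step of an at least 100-fold lower number from compound 1 to compound 2 (2.02 log units; beyond the scatter) shows how far apart the two other groups themselves stand. Seen in reverse, leaving the cyano group for either of the other groups meant a large loss in both cases. For compound 4 a drop beyond the scatter is expected, though a smaller one than either of those, and the expected step is an at least 2.5-fold lower number from compound 3 to compound 4 (0.39 log units; beyond the scatter). Compound 4 is therefore estimated at 20 h, with a range from 3 h to 60 h.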

Compound 4, half-life: > 50 h
Compound 4: only a limit was reported; the forecaster's own chance of this, stated with the estimate: 35%; middle value at least 2.5-fold (0.39 log units) away from the limit.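

In this assay, the change to oxiran-2-yl on this aromatic carbon gives an at least 2900-fold higher number from compound 2 to compound 4 (3.46 log units; beyond the scatter) and an at least 27-fold higher number from compound 1 to compound 4 (1.44 log units; beyond the scatter), so cyano is no longer the only group shown at this place to stand clear of the other two groups. Compound 4 reaches a limit of the assay, and it is the same limit as that of compound 3: the limit of > 50 h in this assay, at which 2 of the 4 values shown sit. The step between these two compounds cannot be read, since both ends are limits, so the expected loss on leaving cyano does not appear, while compound 1 and compound 2 remain the cases where leaving cyano meant a large loss.

As far as these compounds go, how long compound 3 and compound 4 last past that limit stays open. Also open, from the compounds shown here alone, is whether a primary amine or an aziridine ring at this place would reach the same limit.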